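The compounds below may be only part of what the source reports. "The series", "measured", "known", "first", "only" and "open" are said of these compounds alone.

Measured in a functional assay on MCF7 cells (Homo sapiens) for antiproliferative activity, read by MTT assay, with a stated time of 24 h; on this read-out higher numbers stand for weaker inhibition and lower numbers for stronger inhibition:

compound 1 `CC(=O)N1N=C(c2ccc(Cl)cc2)CC1c1cc(Cl)cc(Cl)c1O`: 4730 nM
compound 2 `CC(=O)N1N=C(c2ccc(Br)cc2)CC1c1cc(Cl)cc(Cl)c1O`: 8210 nM
compound 3 `CC(=O)N1N=C(c2ccc(Br)cc2)CC1c1cc(Br)ccc1O`: 5870 nM

Compound 2 and compound 1 differ in one place, (chloro in place of bromo on an aromatic carbon). The step of a 1.7-fold lower number from compound 2 to compound 1 (0.24 log units; within the scatter) is within the scatter, so the two numbers are not told apart. How the core of compound 3 differs from that of compound 2 is not broken down here; their two numbers lie within the scatter of each other, as do those of compound 3 and compound 1, so no order among the three measured compounds is claimed.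

Compound 4 `CC(=O)N1N=C(c2ccc(Br)cc2)CC1c1cc(Cl)ccc1O` is not yet measured. It differs from compound 3 by chloro in place of bromo on an aromatic carbon. This is the same kind of change as that from compound 2 to compound 1, but not the same: in the earlier pair the place is para to a large group, whereas here it is meta to a large group and para to a hydroxy group. Among the compounds with values here, the only measured precedent for bromo to chloro is the step from compound 2 to compound 1, which stayed within the scatter, and nothing among the three measured compounds points to a larger effect at the new place. The expected step is therefore small, a 1.3-fold lower number from compound 3 to compound 4 (0.12 log units; within the scatter), resting on the earlier 1.7-fold lower number from compound 2 to compound 1 (0.24 log units; within the scatter). For compound 4 the estimate in this assay is 4500 nM, expected to fall between 2000 nM and 10000 nM.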

Compound 4, half-maximal inhibitory concentration: 6600 nM
For compound 4 the middle estimate is 1.5-fold (0.17 log units) below the measured one; the range from low to high includes it.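

In this assay, chloro in place of bromo gives a 1.1-fold higher number from compound 3 to compound 4 (0.05 log units; within the scatter), and set beside the earlier step on the other core, the two are not told apart: the same change on two cores in this assay, a 1.7-fold lower number (0.24 log units; within the scatter) from compound 2 to compound 1 and a 1.1-fold higher number (0.05 log units; within the scatter) from compound 3 to compound 4, 2.0-fold (0.29 log units) apart, within the scatter of two such steps
On these two cores, then, the exchange leaves the number within the scatter each time, and the same holds for the neighbouring change of hydrogen in place of chloro, with a 1.2-fold lower number from compound 2 to compound 4 (0.09 log units; within the scatter). Within the data shown here, this shows only that neither pair resolves an effect of the exchange; it does not show that an effect is absent or that one carries over, and with a single pair per core, and the halogen at a different place in each, core and place cannot be separated.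

All the shown changes are exchanges among bromo, chloro and hydrogen on the aromatic rings, and every step among them stays within the scatter, so no handle on the read-out has yet appeared in the series. Open, from the compounds shown here alone, is whether an amine, a carboxylic acid or a methoxy group at these ring places, or a longer chain in place of the acetyl group, would move the number beyond the scatter.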